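Varying the aryl group on the amine nitrogen in a ring

The source may report more compounds than this note shows. Statements on the series, on what has been measured and on what is new or still open speak of the compounds shown alone.

Measured so far:
compound 1 `Nc1scc(CN2CCN(c3cccc(Cl)c3Cl)CC2)c1C(=O)c1ccc(Cl)cc1`: in a functional assay on CHO cells with adenosine receptor A1 (Homo sapiens) as the target, read by cAMP accumulation and immunoassay, with a stated time of 6 min, tested at 1 uM (a higher number here means a weaker effect of the compound at the concentration tested, a lower number a stronger effect), compound 1 gives -57%
compound 2 `Nc1scc(CN2CCN(c3cccc(C(F)(F)F)c3)CC2)c1C(=O)c1ccc(Cl)cc1`: compound 2 gives -72%
compound 3 `Nc1scc(CN2CCN(c3cccc(F)c3F)CC2)c1C(=O)c1ccc(Cl)cc1`: compound 3 gives -66%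

Compound 3 stands second highest of the three numbers. Its nearest neighbour is compound 2, with a number 6 percentage points higher from compound 2 to compound 3 (within the scatter), and a number 9 percentage points lower from compound 1 to compound 3 (within the scatter) also lies within the scatter. Only a number 15 percentage points lower from compound 1 to compound 2 (beyond the scatter) is beyond the scatter, and modestly so.

Compound 4 `Nc1scc(CN2CCN(c3ccc(F)c(Cl)c3)CC2)c1C(=O)c1ccc(Cl)cc1` differs from compound 3 by 3-chloro-4-fluorophenyl in place of 2,3-difluorophenyl on an amine nitrogen in a ring. All three measured steps are exchanges of the aryl group on an amine nitrogen in a ring and so bear on this change; two were within the scatter and one modestly beyond it. The step is therefore expected to be small, with no clear direction, estimated as a number 1 percentage points higher from compound 3 to compound 4 (within the scatter). Compound 4 is expected to give -65%, within -80% to -50%.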

Compound 4, a percentage reported as activity, at one concentration (the size of the read-out at that concentration, not a potency): -60%
Estimate against measurement, compound 4: 5 percentage points below; the range from low to high includes it.
By their numbers in this assay, from the lowest: compounds 2, 3, 4 and 1 (each within the scatter of the next, the first and the last beyond it).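

Changing the halogen pattern on the aryl group on the amine nitrogen in a ring, here with 3-chloro-4-fluorophenyl carrying chlorine and fluorine together, leaves the read-out in this assay close to those of the other dihalophenyl compounds (a number 6 percentage points higher from compound 3 to compound 4 (within the scatter); a number 3 percentage points lower from compound 1 to compound 4 (within the scatter)). The 3-(trifluoromethyl)phenyl group now stands apart from two of these groups, modestly (a number 12 percentage points higher from compound 2 to compound 4 (beyond the scatter)), while compound 3 remains the exception, within the scatter of compound 2. No measurement shown accounts for these steps. As far as these compounds go, whether a methoxy group or an amine on the aryl ring would keep this narrow spread remains open.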